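Swapping a para substituent on the pyrazoline aryl

The compounds below may be only part of what the source reports. "The series", "measured", "known", "first", "only" and "open" are said of these compounds alone.

The shared core is shown by compound 1 `Cn1c(N2N=C(c3ccccc3)CC2c2ccccc2)nc(-c2ccccc2)c(C#N)c1=O`, and in a functional assay on A549 cells (Homo sapiens) for antiproliferative activity, with a stated time of 72 h (on this read-out higher numbers stand for weaker inhibition and lower numbers for stronger inhibition), compound 1 gives 52900 nM. Compound 2 `Cn1c(N2N=C(c3ccccc3)CC2c2ccc(Cl)cc2)nc(-c2ccccc2)c(C#N)c1=O` carries a chloro on the same aromatic ring, and in this assay compound 2 gives 3250 nM. That single change produced a 16-fold lower number from compound 1 to compound 2 (1.21 log units; beyond the scatter), so compound 2 holds the lowest number of the two measured compounds. Compound 3 `COc1ccc(C2CC(c3ccccc3)=NN2c2nc(-c3ccccc3)c(C#N)c(=O)n2C)cc1` differs from compound 2 by methoxy in place of chloro on an aromatic carbon. Going by the values given here, only one measured step exists here, the large gain from hydrogen to chloro, and no step tells how a methoxy compares with a chloro at this position. A substituent at this carbon clearly matters, but its identity may matter too, so the expectation for compound 3 is a 2.5-fold higher number from compound 2 to compound 3 (0.39 log units; beyond the scatter), a moderate loss. Compound 3 is therefore estimated at 8000 nM, within a range from 2000 nM to 30000 nM.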

Compound 3, half-maximal inhibitory concentration: 1760 nM
For compound 3 the middle estimate is 4.5-fold (0.66 log units) above the measured one, outside the stated range (below it).
By their numbers in this assay, from the lowest: compounds 3 and 2 (each within the scatter of the next); then compound 1.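

In this assay, replacing chloro with methoxy gives a 1.8-fold lower number from compound 2 to compound 3 (0.27 log units; within the scatter), so these two groups cannot be told apart at this carbon. Measured against the hydrogen of compound 1, methoxy gives a 30-fold lower number from compound 1 to compound 3 (1.48 log units; beyond the scatter), a large step of the same kind as a 16-fold lower number from compound 1 to compound 2 (1.21 log units; beyond the scatter), which shows that the gain seen with chloro is not limited to that one group. No supporting data are available to explain why these two different groups give such similar results.

From the compounds shown here alone, whether an amine, a carboxylic acid or a longer chain such as butoxy on this same carbon would also give a large step from hydrogen remains open. Going by these compounds, it is also open whether the result would hold on cells other than A549.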